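The compounds below may be only part of what the source reports. "The series", "measured", "known", "first", "only" and "open" are said of these compounds alone.

Measured compounds:
compound 1 `CCOC(=O)c1nn(-c2ccc(C(C)(C)C)cc2)c(=O)c2c(N)scc12` — 9750 nM
compound 2 `CCOC(=O)c1nn(-c2ccc(O)cc2)c(=O)c2c(N)scc12` — 7100 nM
compound 3 `CCOC(=O)c1nn(-c2ccc(OC(C)=O)cc2)c(=O)c2c(N)scc12` — 2500 nM

All three share one core and differ only in the substituent on the aromatic ring attached to it. In an assay on CHO-K1 cells with adenosine receptor A1 (Homo sapiens) as the target (a higher number here means that more compound is needed for the effect, a lower number that less compound is needed), compound 3 gives the lowest number of the three: a 2.8-fold lower number from compound 2 to compound 3 (0.45 log units; beyond the scatter) and a 3.9-fold lower number from compound 1 to compound 3 (0.59 log units; beyond the scatter), both beyond the scatter, while a 1.4-fold lower number from compound 1 to compound 2 (0.14 log units; within the scatter) stays within it.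

Compound 4 `CCOC(=O)c1nn(-c2ccc(OS(=O)(=O)C(F)(F)F)cc2)c(=O)c2c(N)scc12` is the next step from compound 3: (trifluoromethyl)sulfonyl in place of acetyl on an oxygen on an aromatic ring. Among the compounds with values here, the one measured step that bears on this position is a 2.8-fold lower number from compound 2 to compound 3 (0.45 log units; beyond the scatter), which shows that a group on that oxygen, in place of hydrogen, moved the number down modestly. Within the data shown here, no measured pair shows what exchanging one such group for another does, so the direction of this step is uncertain; a change of at most modest size, in either direction, is the expectation for this assay, and the estimate leans only slightly downward.

Compound 4 is therefore expected to give about 2000 nM in this assay, with a range from 700 nM to 6000 nM. This estimate corresponds to an expected step of a 1.3-fold lower number from compound 3 to compound 4 (0.10 log units; within the scatter).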

Compound 4, half-maximal effective concentration: 4900 nM
The estimate for compound 4 lay 2.5-fold (0.39 log units) below the measured number, within the range that was stated.
By their numbers in this assay, from the lowest: compounds 3, 4, 2 and 1 (each within the scatter of the next, the first and the last beyond it).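

In this assay, within the data shown here, the first measured exchange of one group on this oxygen for another gives a 2.0-fold higher number from compound 3 to compound 4 (0.29 log units; within the scatter) and so does not separate acetyl from (trifluoromethyl)sulfonyl. A group on the oxygen is not enough by itself to move the number beyond the scatter: a 1.4-fold lower number from compound 2 to compound 4 (0.16 log units; within the scatter) and a 2.0-fold lower number from compound 1 to compound 4 (0.30 log units; within the scatter) both stay within it, while a 2.8-fold lower number from compound 2 to compound 3 (0.45 log units; beyond the scatter) and a 3.9-fold lower number from compound 1 to compound 3 (0.59 log units; beyond the scatter) lie beyond it, so among the groups shown only acetyl gives a step of that size. No supporting data are available to explain this difference between the two groups.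

On these data alone, it remains open whether a longer acyl chain such as propanoyl, or a methyl group on the same oxygen, would follow acetyl or (trifluoromethyl)sulfonyl. An amine or a carboxylic acid in place of the oxygen-linked groups on the aromatic ring is also untested in these compounds.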